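Extending methoxy to ethoxy on a trypsin inhibitor

The source may hold more compounds than are shown below. What is called first, only, known or untested is meant among the compounds shown, and "the series" means these compounds.

Compound 1, `CCc1cccc(-c2ccc(C(=O)NC(/C=C/c3ccccc3)C(Cc3cccc(C(=N)N)c3)C(=O)OC)cc2)c1`, gives 2600 nM in an assay on isolated protein (Oryctolagus cuniculus) for inhibition of Trypsin (Homo sapiens); on this read-out lower numbers stand for stronger inhibition and higher numbers for weaker inhibition.
Compound 2, `COC(=O)C(Cc1cccc(C(=N)N)c1)C(/C=C/c1ccccc1)NC(=O)c1ccc(-c2ccccc2OC)cc1`, gives 1800 nM in this assay.

Only these two compounds have been measured, and their numbers cannot be separated: the change from compound 1 to compound 2 is a 1.4-fold lower number from compound 1 to compound 2 (0.16 log units; within the scatter), which was a swap of one aromatic group for another on the shared core. Compound 2 therefore stands on a par with compound 1, neither ahead nor behind it.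

Compound 3, `CCOc1ccccc1-c1ccc(C(=O)NC(/C=C/c2ccccc2)C(Cc2cccc(C(=N)N)c2)C(=O)OC)cc1`, is not yet measured. It differs from compound 2 by methyl in place of hydrogen on a saturated chain carbon bound to an oxygen on an aromatic ring, so the methoxy group becomes an ethoxy group.

Going by the values given here, no measured step touches this spot; the single step known, from compound 1 to compound 2, changed a different part of the molecule and stayed within the scatter. There is thus no basis for predicting a shift in either direction, and the expectation is that compound 3 in this assay will sit close to compound 2, with an estimated step of no change at the digits printed from compound 2 to compound 3 (within the scatter). The estimated value for compound 3 is 1800 nM, with a range from 900 nM to 3600 nM.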

Compound 3, half-maximal inhibitory concentration: 1800 nM
Compound 3: the middle estimate sits on the measured number at the digits printed; measured number inside the range.
By their numbers in this assay, from the lowest: compounds 2, 3 and 1 (each within the scatter of the next).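

In this assay, lengthening the methoxy group to an ethoxy group gives no change at the digits printed from compound 2 to compound 3 (within the scatter), so one added methyl on the saturated chain carbon bound to an oxygen on an aromatic ring leaves the number within the scatter. The exchange of 3-ethylphenyl for 2-ethoxyphenyl gives a 1.4-fold lower number from compound 1 to compound 3 (0.16 log units; within the scatter), which means that all three aromatic groups tried so far on the shared core give numbers that cannot be separated on this read-out. No supporting data are available to explain this flat result.

The compounds shown leave open how far this tolerance extends, since a single methyl is a small addition and a longer chain such as propoxy or butoxy could still move the number beyond the scatter. They also leave open whether a different kind of group in the same place, such as a hydroxyl group, an amine or a carboxylic acid, would read any differently from the methoxy and ethoxy groups.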